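The source may report more compounds than this note shows. Statements on the series, on what has been measured and on what is new or still open speak of the compounds shown alone.

Working notes on the series. Compound 1 `Cc1csc(N)c1C(=O)c1ccc(Cl)cc1` gives 1% in an assay on CHO cells for displacement of a labelled ligand from adenosine receptor A3 (Homo sapiens), read by scintillation counting, tested at 10 uM; a lower number here means less inhibition, a higher number more inhibition at the concentration tested (going by the name of the read-out). Compound 2 `CC(C)(C)Cc1csc(N)c1C(=O)c1ccc(Cl)cc1` gives 5% in this assay, and compound 3 `CC(C)(C)Cc1c(-c2ccccn2)sc(N)c1C(=O)c1ccc(Cl)cc1` gives 1%. Compound 2 stands apart from neither of the other two beyond the usual scatter: the step of a number 4 percentage points higher from compound 1 to compound 2 (within the scatter) and the step of a number 4 percentage points lower from compound 2 to compound 3 (within the scatter) are both small. Compound 4 `CC(C)(C)Cc1csc(N)c1C(=O)c1ccc(Cl)c(Cl)c1` differs from compound 2 by chloro in place of hydrogen on an aromatic carbon. Among the measured compounds shown here, no measured step touches the ring that carries the chloro group, so neither of the two small steps bears directly on this change; they only show that the series so far sits close to no inhibition. Expected for compound 4 in this assay: 6%, ranging from 0% to 18%, a step of a number 1 percentage points higher from compound 2 to compound 4 (within the scatter) within the scatter.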

Compound 4, a percentage reported as inhibition, at one concentration (the size of the read-out at that concentration, not a potency): 10%
Compound 4: the middle estimate sits 4 percentage points below what was measured; the measured number falls inside the stated range.
By their numbers in this assay, from the lowest: compounds 1, 3, 2 and 4 (each within the scatter of the next).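

Among the compounds shown here, the second chloro, placed ortho to a chloro group and meta to a large group, gives the first reading on the ring that carries the chloro group: in this assay the change gives a number 5 percentage points higher from compound 2 to compound 4 (within the scatter) and leaves the series close to no inhibition. This position therefore accepts chloro in place of hydrogen without a step beyond the scatter. Nothing available bears on what lies behind this small step. Still open, on these data alone, is whether an amine, a methoxy group or a carboxylic acid at this position would give a step beyond the scatter.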